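Swapping the pyridine arm of an adenosine receptor ligand

A few compounds are considered here, and "the series" means these few. Any claim that something is new, unique, unknown or untested is made for them only; others in the source may bear on it.

Three compounds have been measured in an assay on CHO cells for displacement of a labelled ligand from adenosine receptor A3 (Homo sapiens), read by scintillation counting, with a stated time of 120 min, tested at 1 uM; a lower number here means less inhibition, a higher number more inhibition at the concentration tested (going by the name of the read-out):

Compound 1 `N#Cc1c(N)nc(SCc2cccnc2)c(C#N)c1-c1ccc(OCC2CC2)cc1` — 19%
Compound 2 `N#Cc1c(N)nc2sc(C(N)=O)c(N)c2c1-c1ccc(OCC2CC2)cc1` — 13%
Compound 3 `N#Cc1c(N)nc(SCC(N)=O)c(C#N)c1-c1ccc(OCC2CCC2)cc1` — 1%

Compound 1 shows the highest number of the three, but compound 2 lies within the scatter of it, so the two cannot be told apart; only compound 3, lower and beyond the scatter, stands clearly away from compound 1. Going by the values given here, none of the measured pairs differ in a single place, so no step has been computed among them. Compound 3 changes both the group on the sulfur-bound chain and the ring on the ether, so its gap to compound 1 mixes two differences.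

Compound 4 `N#Cc1c(N)nc(SCC2=NCCN2)c(C#N)c1-c1ccc(OCC2CC2)cc1` is the next compound. It differs from compound 1 as follows: a group of 5 heavy atoms (3 carbon, 2 nitrogen; one five-membered non-aromatic ring with 2 hetero atoms) in place of a group of 6 heavy atoms (5 carbon, 1 nitrogen; one six-membered aromatic ring with 1 hetero atom), on a saturated chain carbon bound to a sulfur.

With no measured step of this kind in hand, the expectation for compound 4 rests on the generally low numbers seen so far. The step of a number 8 percentage points lower from compound 1 to compound 4 (within the scatter) is expected to be a modest drop, not beyond the scatter. Compound 4 is thus expected to give about 11%, with a range from 0% to 26%.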

Compound 4, a percentage reported as inhibition, at one concentration (the size of the read-out at that concentration, not a potency): 6%
Compound 4: the middle estimate sits 5 percentage points above what was measured, within the range that was stated.
By their numbers in this assay, from the lowest: compounds 3, 4, 2 and 1 (each within the scatter of the next, the first and the last beyond it).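

Going by these compounds alone, this is the first step read at this position: in this assay the result is a number 13 percentage points lower from compound 1 to compound 4 (beyond the scatter) when the five-membered non-aromatic ring with 2 hetero atoms takes the place of pyridin-3-yl, on a saturated chain carbon bound to a sulfur. Within the data shown here, the group held on that carbon therefore bears on the read-out, which the earlier compounds could not show, since none of them differed from another in one place alone. No measurement at hand explains the step, and it cannot be assigned to any one difference between the two groups.

On these data alone, whether a phenyl ring, with no ring nitrogen, would stay closer to compound 1 or to compound 4 remains open. So does the outcome for a simple amine or a carboxylic acid on that same chain carbon.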